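The source may hold more compounds than are shown below. What is called first, only, known or untested is meant among the compounds shown, and "the series" means these compounds.

Compound 1, `CC(=O)c1ccc(NC(=O)Nc2cc(C)nc3ccccc23)cc1`: in an ADME assay on HEK293 cells (Homo sapiens) for cytotoxicity, with a stated time of 72 h (a lower number here means that less compound is needed, a higher number that more compound is needed for the effect), compound 1 gives only a limit of the assay, > 25000 nM.
Compound 2, `Cc1cc(NC(=O)Nc2ccccc2N)c2ccccc2n1`: compound 2 likewise gives only a limit, > 25000 nM.
Compound 3, `Cc1cc(NC(=O)Nc2ccc(C(F)(F)F)cc2)c2ccccc2n1`: compound 3 gives 25000 nM.

Compound 2 thus stands at the limit, as the limit of > 25000 nM in this assay, at which 2 of the 3 values shown sit, records, while compound 3 sits at the same number without a limit sign. Among the measured compounds shown here, the single measured step, a number no higher from compound 1 to compound 3 (the limit leaves the size open), exchanges a different group at a different place and therefore says nothing direct about fluoro in place of amino. The new compound 4, `Cc1cc(NC(=O)Nc2ccccc2F)c2ccccc2n1`, differs from compound 2 by fluoro in place of amino on an aromatic carbon. For the measured compounds named here, no measured step touches that place, so no shift beyond the scatter is expected; because the limit of > 25000 nM in this assay, at which 2 of the 3 values shown sit, already holds compound 2, the expected step is a number no higher from compound 2 to compound 4 (the limit leaves the size open). Compound 4 is estimated at 25000 nM, between 12000 nM and 50000 nM, most likely reported again as a limit.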

Compound 4, half-maximal effective concentration: > 25000 nM
Compound 4 was reported as a limit; the forecaster's own chance of this, stated with the estimate: 70%; the middle value lies on the limit itself.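

No step can be read from compound 2 to compound 4, because both sit at the same limit: the limit of > 25000 nM in this assay, at which 3 of the 4 values shown sit. As far as these compounds go, what concentration compound 2 and compound 4 actually need for the effect in this assay stays open.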